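The compounds below may be only part of what the source reports. "The series", "measured", "known", "first", "only" and "open" are said of these compounds alone.

Among the compounds with values here, compound 1 `CC(C)=CCn1c(CN2CCN(C(=O)C3CC3)CC2)nc2ccccc21` stands at the high end of the numbers measured so far in an assay on isolated protein for inhibition of aldehyde dehydrogenase 1A1 (Homo sapiens), read by spectrophotometry; a higher number here means a weaker inhibitor, a lower number a stronger inhibitor: compound 1 gives 1500 nM, whereas compound 2 `CCC(=O)N1CCN(Cc2nc3ccccc3n2Cc2cccc(C)c2)CC1` gives 626 nM and compound 3 `Cc1cccc(Cn2c(CN3CCN(C(=O)C(C)C)CC3)nc3ccccc32)c1` gives 458 nM. Within the data shown here, the only step measured within the set, a 1.4-fold lower number from compound 2 to compound 3 (0.14 log units; within the scatter), concerns the acyl group on the piperazine and does not touch the substituent on the aromatic nitrogen, so it gives no direct guidance here.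

Compound 4 `O=C(C1CC1)N1CCN(Cc2nc3ccccc3n2Cc2cccc(Cl)c2)CC1` differs from compound 1 at that substituent: 3-chlorophenyl in place of 2-methylprop-1-en-1-yl on a saturated chain carbon bound to an aromatic nitrogen. Among the measured compounds shown here, no measured step covers this change. Compounds 2 and 3, whose group at the same place is an aromatic ring rather than the 2-methylprop-1-en-1-yl of compound 1, both give lower numbers than compound 1 in this assay, but they also differ from compound 1 in the acyl group, so only their values, not a clean step, can be read. The 3-chlorophenyl itself has not been tested anywhere in the series.

On this basis compound 4 is expected to give 650 nM in this assay, within 250 nM to 1700 nM. That estimate means an expected 2.3-fold lower number from compound 1 to compound 4 (0.36 log units; beyond the scatter), a downward move broadly toward where compounds 2 and 3 sit, held with wide uncertainty.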

Compound 4, half-maximal inhibitory concentration: 2110 nM
For compound 4 the middle estimate is 3.2-fold (0.51 log units) below the measured one; the whole stated range lies below it.
By their numbers in this assay, from the lowest: compounds 3 and 2 (each within the scatter of the next); then compounds 1 and 4 (each within the scatter of the next).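

Within the data shown here, the change at this place gives a 1.4-fold higher number from compound 1 to compound 4 (0.15 log units; within the scatter) in this assay and is the first measured step at the substituent on a saturated chain carbon bound to an aromatic nitrogen. With the rest of compound 1 held fixed, 3-methylbut-2-en-1-yl and 3-chlorobenzyl cannot be told apart at this place, even though the entering group brings a six-membered aromatic ring and more heavy atoms, so this pair gives no support for reading an aromatic ring here as lowering the number by itself. No measured evidence bears on why these two groups cannot be separated.

Still open, as far as these compounds go, is whether any other group at this place, such as an unsubstituted benzyl, a longer chain or a chain ending in an amine or a carboxylic acid, would separate from these two beyond the scatter. Also open, from the compounds shown here alone, is what the chlorine contributes, which would need hydrogen or methyl in its stead on the same ring with the acyl group of compound 4 unchanged.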